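Phenyl for methyl on the ring nitrogen: cytotoxicity notes

A few compounds are considered here, and "the series" means these few. Any claim that something is new, unique, unknown or untested is made for them only; others in the source may bear on it.

Measured compounds:
compound 1 `Cc1nn(C)c2ncc(CCCO)cc12`: 7%
compound 2 `CCO[C@@H](C1=CC2C(C)=NN(c3ccccc3)C2N=C1)[C@H](O)[C@@H](O)CO`: 9%

In a functional assay on THP-1 cells (Homo sapiens) for cytotoxicity, tested at 10 uM (a lower number here means less inhibition, a higher number more inhibition at the concentration tested (going by the name of the read-out)), compound 1 has the lowest of the two numbers, and compound 2 lies within the scatter of it, so no order between them is claimed. Within the data shown here, no pair of measured compounds differs in a single place, so no measured step is known. Compound 3 `Cc1nn(-c2ccccc2)c2ncc(CCCO)cc12` differs from compound 1 by phenyl in place of methyl on an aromatic nitrogen. Compound 2, which also carries a phenyl on an aromatic nitrogen, gives 9%, a low number. Because compound 2 gives 9% no step beyond the scatter is expected. The expected step is a number 3 percentage points higher from compound 1 to compound 3 (within the scatter). For compound 3 the estimate is 10%, within 0% to 25%.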

Compound 3, a percentage reported as inhibition, at one concentration (the size of the read-out at that concentration, not a potency): 16%
Compound 3: middle estimate off by 6 percentage points, on the low side; the measured number falls inside the stated range.
By their numbers in this assay, from the lowest: compounds 1, 2 and 3 (each within the scatter of the next).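

In this assay, the step for phenyl in place of methyl on the aromatic nitrogen is a number 9 percentage points higher from compound 1 to compound 3 (within the scatter) and gives the series its first measured single-place comparison. On the core of compound 1, this position therefore accepts one six-membered aromatic ring of carbon only without a step beyond the scatter. Nothing on hand offers an explanation for this result.

Still open, as far as these compounds go, is whether a phenyl bearing an amine or a carboxylic acid would also stay within the scatter. The same applies to a longer chain on this nitrogen.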